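The source may report more compounds than this note shows. Statements on the series, on what has been measured and on what is new or still open speak of the compounds shown alone.

Compound 1 `CC(C)Cc1ccc2c(NCCCNCc3ccco3)ccnc2c1` gives 23 10^-6 cm/s in an ADME assay for permeability, using PAMPA, with a stated time of 30 min, at pH 7.4; a higher number here means that the compound crosses the layer faster, a lower number that the compound crosses the layer more slowly. Compound 2 `CC(C)CCc1ccc2c(NCCCNCc3ccco3)ccnc2c1` gives 23 10^-6 cm/s in this assay.

Compound 2 thus stands level with compound 1, and the step of no change at the digits printed from compound 1 to compound 2 (within the scatter) lies within the scatter. Compound 3 `COc1ccccc1Oc1ccc2c(NCCCNCc3ccco3)ccnc2c1` differs from compound 2 by 2-methoxyphenoxy in place of isopentyl on an aromatic carbon. Among the compounds with values here, the only measured step concerns a different change, so no measured step bears directly on this one, and nothing measured points to a shift in this assay. Compound 3 is therefore expected to stay near compound 2, with an estimated step of a 1.3-fold lower number from compound 2 to compound 3 (0.11 log units; within the scatter). Compound 3 is estimated at 18 10^-6 cm/s, in a range from 9 10^-6 cm/s to 35 10^-6 cm/s.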

Compound 3, apparent permeability: 317 10^-6 cm/s
Compound 3: the middle estimate sits 18-fold (1.25 log units) below what was measured; measured number outside the range, above it.
By their numbers in this assay, from the lowest: compounds 1 and 2 (each within the scatter of the next); then compound 3.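

The isobutyl and isopentyl groups left the number unchanged, but this position is not indifferent to what it carries: in this assay, 2-methoxyphenoxy in place of isopentyl gives a 14-fold higher number from compound 2 to compound 3 (1.14 log units; beyond the scatter), and in place of isobutyl gives a 14-fold higher number from compound 1 to compound 3 (1.14 log units; beyond the scatter). A change on this aromatic carbon can therefore move the read-out far beyond the scatter. Nothing available accounts for the size of this step.

The compounds shown do not separate the contributions of the methoxy group, the aromatic ring and the linking oxygen. From the compounds shown here alone, it remains open whether an unsubstituted phenoxy group or an amine at this position would give a similar number.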